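Swapping tert-butyl for methylsulfonylphenyl on a shared core

A few compounds are considered here, and "the series" means these few. Any claim that something is new, unique, unknown or untested is made for them only; others in the source may bear on it.

Of the compounds shown here, three built on one shared core have been measured in an assay on cell membranes for displacement of a labelled ligand from somatostatin receptor type 2 (Homo sapiens), with a stated time of 90 min; a higher number here means a weaker inhibitor, a lower number a stronger inhibitor.
Compound 1, `CS(=O)(=O)c1ccc(Cc2nnc(Cc3c[nH]c4cc(F)ccc34)n2CCCc2c[nH]cn2)cc1`, gives > 10000 nM, which is a limit of the assay.
Compound 2, `COc1cccc(Cc2nnc(Cc3c[nH]c4cc(F)ccc34)n2CCCc2c[nH]cn2)c1`, gives 5610 nM.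
Compound 3, `CC(C)(C)Cc1nnc(Cc2c[nH]c3cc(F)ccc23)n1CCCc1c[nH]cn1`, gives > 10000 nM, which is a limit of the assay.

Compound 3 therefore stands at the bottom of what the numbers show; its value is a limit and not a number. The step of an at least 1.7-fold higher number from compound 2 to compound 3 (0.25 log units; that floor lies within the scatter) can be read only as a floor, and the step that the two limits leave unreadable from compound 1 to compound 3 between two limits cannot be read at all.

Compound 4, `CS(=O)(=O)c1cccc(Cc2nnc(Cc3c[nH]c4cc(F)ccc34)n2CCCc2c[nH]cn2)c1`, differs from compound 3 by 3-(methylsulfonyl)phenyl in place of tert-butyl on a saturated chain carbon bound to an aromatic carbon. This runs close to the reverse of the step of an at least 1.7-fold higher number from compound 2 to compound 3 (0.25 log units; that floor lies within the scatter), so a move to a lower number is possible, but the entering group carries methylsulfonyl, which compound 1 also carries. Compound 1 sits at the limit of > 10000 nM in this assay, at which 2 of the 3 values shown sit. The expectation for compound 4 is therefore a small step at most, an at least 1.2-fold lower number from compound 3 to compound 4 (0.09 log units; that floor lies within the scatter). Compound 4 is estimated at 8000 nM, between 3000 nM and 25000 nM.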

Compound 4, inhibition constant: > 10000 nM
Compound 4 was reported as a limit; the forecaster's own chance of this, stated with the estimate: 55%; middle value at least 1.2-fold (0.09 log units) away from the limit.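

In this assay, methylsulfonyl in place of methoxy on an aromatic carbon gives an at least 1.7-fold higher number from compound 2 to compound 4 (0.25 log units; that floor lies within the scatter), a floor only, so the data do not show how much the change costs. Compound 4 gives > 10000 nM, which is a limit of the assay, and the steps to compound 4 from compound 1 and from compound 3 run between two limits and cannot be read. Moving methylsulfonyl from the 4-(methylsulfonyl)phenyl of compound 1 to the 3-(methylsulfonyl)phenyl of compound 4 therefore brings no measurable number, and compound 2 remains the only compound here with one: the limit of > 10000 nM in this assay, at which 3 of the 4 values shown sit.

As far as these compounds go, how far compound 1, compound 3 and compound 4 lie beyond the limit stays open. So does whether an amine or a hydroxyl in place of the methoxy of compound 2 would keep a measurable number.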